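Working notes: cyano in place of acetyl

This account rests on a few compounds, and the source may have more. Where it says the series, first, only, none or still open, it means among the compounds named here.

Values in a functional assay (Nicotiana tabacum); a higher number here means a weaker inhibitor, a lower number a stronger inhibitor:
- compound 1 `CSc1nc(Nc2ccccc2)c2cccnc2n1`: 15900 nM
- compound 2 `CSc1nc(Nc2ccc(F)cc2)c2cccnc2n1`: 2620 nM
- compound 3 `CSc1nc(Nc2ccc(C(C)=O)cc2)c2cccnc2n1`: 8960 nM

Compound 3 holds the middle number of the three at 8960 nM, though the nearest gap is only a 1.8-fold lower number from compound 1 to compound 3 (0.25 log units; within the scatter). The next change gives compound 4 `CSc1nc(Nc2ccc(C#N)cc2)c2cccnc2n1`, with cyano in place of acetyl on an aromatic carbon. Replacing hydrogen gave a 6.1-fold lower number from compound 1 to compound 2 (0.78 log units; beyond the scatter). For the measured compounds named here, the only measured exchange of one substituent for another is a 3.4-fold higher number from compound 2 to compound 3 (0.53 log units; beyond the scatter), a modest step. With so few steps to draw on, no step beyond the scatter is expected in this assay. The estimated step is a 1.5-fold lower number from compound 3 to compound 4 (0.17 log units; within the scatter). Compound 4 is expected at 6000 nM, with an estimated range of 2500 nM to 15000 nM.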

Compound 4, half-maximal inhibitory concentration: 7560 nM
The estimate for compound 4 lay 1.3-fold (0.10 log units) below the measured number, and the stated range covers the measured number.
By their numbers in this assay, from the lowest: compound 2; then compounds 4, 3 and 1 (each within the scatter of the next, the first and the last beyond it).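

In this assay, cyano and acetyl cannot be told apart at this position on the aromatic carbon (a 1.2-fold lower number from compound 3 to compound 4 (0.07 log units; within the scatter)), so the smaller group with the triple bond changes nothing readable here. Against hydrogen, cyano gives a step beyond the scatter (a 2.1-fold lower number from compound 1 to compound 4 (0.32 log units; beyond the scatter)), whereas acetyl stayed within it, yet fluoro still keeps a lead over cyano (a 2.9-fold higher number from compound 2 to compound 4 (0.46 log units; beyond the scatter)). No evidence at hand explains these steps. Still open, on these data alone, is whether chloro would match fluoro, and whether an amine or a carboxylic acid at this position would give a lower number than fluoro.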